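A few compounds are considered here, and "the series" means these few. Any claim that something is new, unique, unknown or untested is made for them only; others in the source may bear on it.

Measured so far:
Compound 1 `O=c1[nH]/c(=N\OCCCc2cccc(F)c2)ccn1[C@@H]1O[C@H](COP(=O)(O)OP(=O)(O)OP(=O)(O)O)[C@@H](O)[C@H]1O` gives 190 nM in a functional assay on 1321-N1 cells for agonist activity at P2Y purinoceptor 2 (Homo sapiens), read by scintillation counting and inositol phosphate accumulation; a lower number here means that less compound is needed, a higher number that more compound is needed for the effect.
Compound 2 `O=c1[nH]/c(=N\OCCCc2ccc(Br)cc2)ccn1[C@@H]1O[C@H](COP(=O)(O)OP(=O)(O)OP(=O)(O)O)[C@@H](O)[C@H]1O` gives 350 nM in this assay.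
Compound 3 `O=c1[nH]/c(=N\OCCCc2ccc([N+](=O)[O-])cc2)ccn1[C@@H]1O[C@H](COP(=O)(O)OP(=O)(O)OP(=O)(O)O)[C@@H](O)[C@H]1O` gives 458 nM in this assay.

Compound 2 stands second highest of the three numbers; the steps of a 1.8-fold higher number from compound 1 to compound 2 (0.27 log units; within the scatter) and a 1.3-fold higher number from compound 2 to compound 3 (0.12 log units; within the scatter) are both within the scatter, and only a 2.4-fold higher number from compound 1 to compound 3 (0.38 log units; beyond the scatter) exceeds it. Compound 4 `C#CCCCO/N=c1/ccn([C@@H]2O[C@H](COP(=O)(O)OP(=O)(O)OP(=O)(O)O)[C@@H](O)[C@H]2O)c(=O)[nH]1` differs from compound 2 thus: ethynyl in place of 4-bromophenyl on a saturated chain carbon, three bonds along the chain from an oxygen. The known steps change only the substituent on the phenyl ring and stay small; none removes the ring itself, so they bear on this change only weakly. In compound 4 the 4-bromophenyl is lost entirely. A step beyond the scatter toward a higher number is expected. Compound 4 is estimated at 800 nM (range 200 nM to 3000 nM), a step of a 2.3-fold higher number from compound 2 to compound 4 (0.36 log units; beyond the scatter).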

Compound 4, half-maximal effective concentration: 168 nM
For compound 4 the middle estimate is 4.8-fold (0.68 log units) above the measured one; measured number outside the range, below it.
By their numbers in this assay, from the lowest: compounds 4, 1, 2 and 3 (each within the scatter of the next, the first and the last beyond it).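

In this assay losing the whole aryl ring at this chain end carries no penalty: ethynyl gives a 2.1-fold lower number from compound 2 to compound 4 (0.32 log units; beyond the scatter) and a 2.7-fold lower number from compound 3 to compound 4 (0.44 log units; beyond the scatter) while a 1.1-fold lower number from compound 1 to compound 4 (0.05 log units; within the scatter) stays within the scatter. Among these four compounds, an aromatic ring on the chain is therefore not needed for the lower numbers. Nothing measured here explains the result.

Open, on these data alone, is whether the triple bond or simply the smaller chain end accounts for this; a plain pentyl chain would separate the two. Also open, as far as these compounds go, is how an amine or a carboxylic acid at the chain end would read.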